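The compounds below may be only part of what the source reports. "The series", "measured", "known", "first", "only" and "open" are said of these compounds alone.

Measured compounds:
compound 1, `O=C(O)CCc1ccc(C#Cc2ccnc(Cl)c2Cc2ccccc2)cc1`, 101%
compound 2, `COc1cc(C#Cc2ccc(CCC(=O)O)cc2)ccn1`, 98%

Of these two numbers in an in vitro functional assay on 1321-N1 cells for agonist activity at Free fatty acid receptor 1 (Homo sapiens), read by fluorescence, spectrophotometry and calcium flux (on this read-out higher numbers stand for larger maximal responses and lower numbers for smaller maximal responses), compound 1 nominally stands at the top, but its nearest neighbour, compound 2, lies within the usual scatter of this reading, so the two cannot be told apart. Compound 3, `C=CCc1c(C#Cc2ccc(CCC(=O)O)cc2)ccnc1Cl`, has not yet been measured in this assay. It differs from compound 1 in one place: vinyl in place of phenyl on a saturated chain carbon bound to an aromatic carbon. Going by the values given here, no measured pair shows how this exchange plays out, so the expectation rests on the two values alone, both of which reach the full response of the reference. The expected change is a number 5 percentage points lower from compound 1 to compound 3 (within the scatter), that is, nothing beyond the scatter in either direction. Compound 3 is accordingly estimated to give 96% in this assay, with a range from 80% to 108%.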

Compound 3, largest response reached (reported as efficacy), in percent of the reference or control that the assay uses: 97%
Compound 3: middle estimate off by 1 percentage points, on the low side, and the stated range covers the measured number.
By their numbers in this assay, from the lowest: compounds 3, 2 and 1 (each within the scatter of the next).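

In this assay, the exchange of phenyl for vinyl on a saturated chain carbon bound to an aromatic carbon, which cut one bond further out reads benzyl to allyl, gives a number 4 percentage points lower from compound 1 to compound 3 (within the scatter). This single pair thus shows that the full response at this position does not require the aromatic ring: the entering group has 2 heavy atoms where the leaving group has 6. Nothing on hand accounts for this outcome.

Going by these compounds, it remains open whether an amine, a hydroxyl group or a longer alkyl chain in the same place would give a response on the same level. The maximal response also leaves unanswered whether benzyl and allyl differ in the concentration needed to reach it.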